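Furan to Dimethoxyphenyl: Cytotoxicity Outlook for a New Analogue

A few compounds are considered here, and "the series" means these few. Any claim that something is new, unique, unknown or untested is made for them only; others in the source may bear on it.

Compound 1 `CC(C)N(Cc1cccc(OCCCCCC(=O)O)c1)C(=O)c1ccc(-c2ccoc2)cc1` has been examined in an ADME assay on BJ cells (Homo sapiens) for cytotoxicity, read by CellTiter-Glo and resazurin assay, with a stated time of 72 h; on this read-out lower numbers stand for an effect already at smaller amounts and higher numbers for an effect only at larger amounts of compound. In this assay compound 1 gives > 26000 nM, which is a limit of the assay rather than a measured number. Among the compounds with values here, compound 2 `CC(C)N(Cc1cccc(OCCCCCC(=O)O)c1)C(=O)c1ccc(-c2cccc(Oc3ccccc3)c2)cc1` is the only other compound with a result. In this assay compound 2 gives > 18700 nM, likewise a limit and not a number. Within the data shown here, compound 1 therefore stands at the limit of > 26000 nM in this assay, at which 1 of the 2 values shown sits, and since both values shown are limits, neither compound can be placed above or below the other, and no step between measured compounds can be computed.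

Compound 3 `COc1cc(OC)cc(-c2ccc(C(=O)N(Cc3cccc(OCCCCCC(=O)O)c3)C(C)C)cc2)c1` differs from compound 1 in one place: 3,5-dimethoxyphenyl in place of furan-3-yl on an aromatic carbon. Among the measured compounds shown here, with both measured compounds sitting at limits, no measured step bears on this exchange, so no direction can be read from the data. No change beyond the usual scatter is expected; the estimated step that the limit leaves unreadable from compound 1 to compound 3 reflects that. Compound 3 is expected to give about 30000 nM in this assay, within a range from 10000 nM to 100000 nM, and most likely the outcome will again be reported only as a limit.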

Compound 3, half-maximal effective concentration: > 26000 nM
Compound 3: no number, only a limit; the forecaster's own chance of this, stated with the estimate: 75%; the middle value does not contradict the limit.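

Within the data shown here, compound 1 and compound 3 are each reported only as a limit in this assay, and no step between the two can be read from these results. The compounds shown leave open the concentration at which compound 1, compound 2 or compound 3 would reach a half-maximal effect on these cells, and whether 3,5-dimethoxyphenyl in place of furan-3-yl shifts that concentration at all.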